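A few compounds are considered here, and "the series" means these few. Any claim that something is new, unique, unknown or untested is made for them only; others in the source may bear on it.

Of the compounds shown here, two have been measured in a functional assay (brain) for displacement of a labelled ligand, with Rattus norvegicus as the target; a lower number here means a stronger inhibitor, a higher number a weaker inhibitor. Compound 1, with the structure `CC[C@]1(c2ccccc2Cl)OC[C@H]([C@@H]2CCCCN2)O1`, gives 14.3 nM in this assay. Compound 2, with the structure `CN1CCCC[C@H]1[C@H]1COC(c2ccccc2)(c2ccccc2)O1`, gives 4400 nM in this assay, the higher of the two numbers, far apart from the number of compound 1; the two differ in several places at once, so nothing more is read from that gap. Compound 3, with the structure `CCN1CCCC[C@H]1[C@H]1COC(c2ccccc2)(c2ccccc2)O1`, has not been measured. It differs from compound 2 in one spot: methyl in place of hydrogen on a saturated chain carbon bound to an amine nitrogen in a ring. Read one bond further out, the methyl becomes an ethyl, so the 1-methylpiperidin-2-yl of compound 2 becomes a 1-ethylpiperidin-2-yl. Among the measured compounds shown here, no measured pair shows what such a change does here, so a step of about the usual scatter, in no clear direction, is expected a 1.3-fold lower number from compound 2 to compound 3 (0.10 log units; within the scatter). In this assay compound 3 is therefore estimated at 3500 nM, between 1200 nM and 10000 nM.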

Compound 3, inhibition constant: 6900 nM
The estimate for compound 3 lay 2.0-fold (0.29 log units) below the measured number; the range from low to high includes it.
By their numbers in this assay, from the lowest: compound 1; then compounds 2 and 3 (each within the scatter of the next).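

In this assay, replacing the 1-methylpiperidin-2-yl of compound 2 with the 1-ethylpiperidin-2-yl of compound 3 gives a 1.6-fold higher number from compound 2 to compound 3 (0.20 log units; within the scatter). Among the compounds shown here, this is the first comparison here between two compounds that differ in only one place, so it is the first direct reading of this position. On this saturated chain carbon bound to an amine nitrogen in a ring, one added methyl leaves the two compounds indistinguishable in this measurement, although a single pair cannot show how far that holds on other cores.

Still open, going by these compounds, is what a longer chain such as propyl, or a larger group such as benzyl, would do at this position. The compounds shown also offer no measured explanation for this result.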